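The compounds below may be only part of what the source reports. "The series", "measured", "known", "first", "only" and "open" are said of these compounds alone.

Measured compounds:
- compound 1 `CC(C)(C)c1ccccc1Oc1ncccc1NC(=O)N[C@H]1CC[C@H](C)CC1`: 7050 nM in a functional assay on cells for antagonist activity at P2Y purinoceptor 1 (Homo sapiens), read by calcium flux; a higher number here means a weaker inhibitor, a lower number a stronger inhibitor
- compound 2 `Cc1ccc(NC(=O)Nc2ccc(OC(F)(F)F)cc2)c(Oc2ccccc2C(C)(C)C)n1`: 210 nM in this assay

Compound 1 gives the highest number of the two in this assay; its nearest neighbour is compound 2, whose number is lower by a gap that lies beyond the scatter. Among the compounds with values here, the two differ in several places at once, so what the gap shows is only that compound 2 is the stronger inhibitor of the pair.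

Compound 3 `CC(C)(C)c1ccccc1Oc1ncccc1NC(=O)NC1CCCC1` has not been measured. Against compound 1 the change is cyclopentyl in place of 4-methylcyclohexyl on an amide-type nitrogen. Within the data shown here, nothing measured isolates this change, so no step is known for it; the record gives no direction for a swap of one non-aromatic ring for another on the amide-type nitrogen.

The working expectation is that compound 3 stays close to compound 1, with the step from compound 1 to compound 3 expected to be a 1.3-fold higher number from compound 1 to compound 3 (0.11 log units; within the scatter), that is within the scatter or a slight move to a higher number. For compound 3 the estimated value in this assay is 9000 nM, in the range 3000 nM to 27000 nM.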

Compound 3, half-maximal inhibitory concentration: 2410 nM
For compound 3 the middle estimate is 3.7-fold (0.57 log units) above the measured one; the measured number lies below the stated range.
By their numbers in this assay, from the lowest: compound 2; then compound 3; then compound 1.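

In this assay, cyclopentyl in place of 4-methylcyclohexyl on an amide-type nitrogen gives a 2.9-fold lower number from compound 1 to compound 3 (0.47 log units; beyond the scatter), a modest step, with the rest of the molecule unchanged. Within the data shown here, this is the first one-place comparison, and it shows that inhibition responds to a swap of one carbon-only non-aromatic ring for another at this nitrogen, with the five-membered ring giving the stronger inhibitor of the pair. No measurement at hand accounts for the step, so it stands as an observation on this one pair only.

Among these compounds, the single change removes the methyl and the two defined stereocentres and also shrinks the ring, so the step cannot be assigned to any one of these, and plain cyclohexyl would be the comparison that separates ring size from the methyl. Also open, on these data alone, are whether a still smaller ring such as cyclobutyl continues the direction, and how an open butyl chain or a ring carrying a hydroxyl group or an amine would compare with cyclopentyl at this nitrogen.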